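A few compounds are considered here, and "the series" means these few. Any claim that something is new, unique, unknown or untested is made for them only; others in the source may bear on it.

Compound 2 `Cc1cc(OCCO)cc(C)c1NC(=O)c1ccc(-c2cc(Cl)ccc2Cl)o1` is the lower of the two compounds measured in an assay on isolated protein for inhibition of sphingosine 1-phosphate receptor 5 (Homo sapiens), tested at 25 uM (a higher number here means more inhibition at the concentration tested (going by the name of the read-out), a lower number less inhibition), where compound 2 gives 60%. Among the compounds with values here, compound 1 `Cc1cc(CN)cc(C)c1NC(=O)c1ccc(-c2cc(Cl)ccc2Cl)o1` gives 90%, and the only measured step, a number 30 percentage points lower from compound 1 to compound 2 (beyond the scatter), came with 2-hydroxyethoxy in place of aminomethyl. Compound 3 `COc1cc(C)c(NC(=O)c2ccc(-c3cc(Cl)ccc3Cl)o2)c(C)c1` differs from compound 2 by hydrogen in place of hydroxymethyl on a saturated chain carbon bound to an oxygen on an aromatic ring. Within the data shown here, no measured step covers this change; the one step seen shows only that 2-hydroxyethoxy sits below aminomethyl. Compound 3 is therefore expected to move little, by about a number 10 percentage points lower from compound 2 to compound 3 (within the scatter). Compound 3 is estimated at 50%, with a range from 25% to 75%.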

Compound 3, a percentage reported as inhibition, at one concentration (the size of the read-out at that concentration, not a potency): 40%
Estimate against measurement, compound 3: 10 percentage points above, within the range that was stated.
By their numbers in this assay, from the lowest: compound 3; then compound 2; then compound 1.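

Replacing hydroxymethyl with hydrogen on a saturated chain carbon bound to an oxygen on an aromatic ring is not a silent change in this assay, giving a number 20 percentage points lower from compound 2 to compound 3 (beyond the scatter) beyond what the opening estimate's central figure suggested. Among the three groups on this aromatic carbon, methoxy now marks the low end, with a number 50 percentage points lower from compound 1 to compound 3 (beyond the scatter) and aminomethyl still at the top. No evidence here explains either drop. Still open, on these data alone, is whether a longer chain ending in hydroxyl would raise the number further. Also open, as far as these compounds go, is how a 2-aminoethoxy group or a carboxylic acid would compare with aminomethyl.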